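The compounds below may be only part of what the source reports. "The series", "measured", "known", "first", "only" and "open" are said of these compounds alone.

Measured compounds:
compound 1, `Cc1[nH]c2ccccc2c1C1=C(Br)C(=O)C(c2c(C)[nH]c3ccccc23)=C(Br)C1=O`: 7 ug/mL
compound 2, `Cc1ccc(-c2[nH]c3ccccc3c2C2=C(Cl)C(=O)C(c3c(C)[nH]c4ccccc34)=C(Cl)C2=O)cc1`: 2.8 ug/mL

The two measured compounds share a core carrying two indole units on a central dihalogenated quinone. In a functional assay on MCF7 cells (Homo sapiens) for antiproliferative activity, read by CCK-8 assay, with a stated time of 48 h (on this read-out higher numbers stand for weaker inhibition and lower numbers for stronger inhibition), compound 1 gives 7 ug/mL, the higher of the two numbers. Compound 2 differs from compound 1 in several places at once. In this assay compound 2 gives 2.8 ug/mL, a lower number that lies beyond the usual scatter; since the two differ in several places at once, no single structural cause for this gap can be read from the data.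

Compound 3, `COc1ccc2[nH]c(C)c(C3=C(Br)C(=O)C(c4c(C)[nH]c5ccccc45)=C(Br)C3=O)c2c1`, has not yet been measured. Compared with compound 1 it carries methoxy in place of hydrogen on an aromatic carbon. Going by the values given here, no measured pair shows the effect of this particular change on its own, so there is nothing in the measured numbers that points to a large step in either direction. The account therefore expects at most a small shift from compound 1 to compound 3 in this assay, likely within the scatter of repeated measurements, with a 1.3-fold lower number from compound 1 to compound 3 (0.10 log units; within the scatter) as the estimated step. Compound 3 is expected to give about 5.5 ug/mL, in a range from 2 ug/mL to 15 ug/mL.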

Compound 3, half-maximal inhibitory concentration: > 25 ug/mL
Compound 3: no number, only a limit; the forecaster's own chance of this, stated with the estimate: 5%; middle value at least 4.5-fold (0.65 log units) away from the limit.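

In this assay compound 3 gives > 25 ug/mL as its reading, and this is a limit of the assay, not a number. Going by these compounds alone, this is the first comparison here in which the compounds differ in only one place, and it shows that methoxy in place of hydrogen on this aromatic carbon, meta to a fused ring and para to a fused ring, is not a silent change: the data give an at least 3.5-fold higher number from compound 1 to compound 3 (0.55 log units; beyond the scatter) in the direction of weaker inhibition. That step is only a lower bound, and its full size cannot be stated, because the reading for compound 3 lies at the limit: the limit of > 25 ug/mL in this assay, at which 1 of the 3 values shown sits.

What the compounds shown leave open is whether this loss belongs to methoxy itself or would also follow from a hydroxyl, an amine or a fluorine atom at the same carbon, or from a methoxy at another carbon of that ring. It also remains open whether methoxy would have a similar effect on compound 2, since no comparison shown tests this change on that compound.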